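Changing one group on the amide nitrogen

A few compounds are considered here, and "the series" means these few. Any claim that something is new, unique, unknown or untested is made for them only; others in the source may bear on it.

In a functional assay on HT-29 cells (Homo sapiens) for cytotoxicity, read by MTT assay, with a stated time of 72 h (a lower number here means a stronger inhibitor, a higher number a weaker inhibitor), three compounds share one core and differ only in the group on an amide-type nitrogen. Compound 1 `COc1ccc(NC(=O)CN2CCN(c3nnc(Cc4ccncc4)c4ccccc34)CC2)cc1OC` gives 40100 nM and compound 2 `O=C(CN1CCN(c2nnc(Cc3ccncc3)c3ccccc23)CC1)Nc1ccc(F)c(C(F)(F)F)c1` gives 1110 nM while compound 3 `Cc1ccc(F)cc1NC(=O)CN1CCN(c2nnc(Cc3ccncc3)c3ccccc23)CC1` gives 470 nM as the lowest number of the three, which makes it the strongest inhibitor of this small set.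

Going by the values given here, compound 4 `O=C(CN1CCN(c2nnc(Cc3ccncc3)c3ccccc23)CC1)Nc1cc(C(F)(F)F)ccc1Cl` has no measurement yet. It is compound 3 with one change 2-chloro-5-(trifluoromethyl)phenyl in place of 5-fluoro-2-methylphenyl on an amide-type nitrogen in which 2-chloro-5-(trifluoromethyl)phenyl takes the place of 5-fluoro-2-methylphenyl on the amide-type nitrogen.

Replacing 3,4-dimethoxyphenyl gave large steps, a 36-fold lower number from compound 1 to compound 2 (1.56 log units; beyond the scatter) and an 85-fold lower number from compound 1 to compound 3 (1.93 log units; beyond the scatter) in turn, but that group plays no part in the new change. The closest guide is a 2.4-fold lower number from compound 2 to compound 3 (0.37 log units; beyond the scatter) and it is only modest. Compound 2 at 1110 nM also carries a trifluoromethyl group, as compound 4 does. A small step toward a higher number is therefore expected in this assay and not a large one. The expected change is a 1.7-fold higher number from compound 3 to compound 4 (0.23 log units; within the scatter) on this reasoning. Compound 4 is estimated at 800 nM with an expected range from 250 nM to 2500 nM as its two ends.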

Compound 4, half-maximal inhibitory concentration: 4810 nM
Compound 4: the middle estimate sits 6.0-fold (0.78 log units) below what was measured, and the stated range ends below it.
By their numbers in this assay, from the lowest: compound 3; then compound 2; then compound 4; then compound 1.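

In this assay, going by these compounds alone, this position on the amide-type nitrogen proves more sensitive than the earlier compounds suggested: swapping one substituted phenyl for another, with no change in the count of hydrogen-bond donors or acceptors, gives a 10-fold higher number from compound 3 to compound 4 (1.01 log units; beyond the scatter). Carrying a trifluoromethyl group does not by itself fix the number, since compound 2 and compound 4 both have one and there is still a 4.3-fold higher number from compound 2 to compound 4 (0.64 log units; beyond the scatter). Even so, 2-chloro-5-(trifluoromethyl)phenyl remains better than 3,4-dimethoxyphenyl, with an 8.3-fold lower number from compound 1 to compound 4 (0.92 log units; beyond the scatter), so all three replacements of 3,4-dimethoxyphenyl give lower numbers, though by quite different amounts.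

Nothing measured here on these compounds explains why the steps differ in size. From the compounds shown here alone, it also stays open which part of 2-chloro-5-(trifluoromethyl)phenyl goes with the higher number, the chlorine or the trifluoromethyl group, and how a plain phenyl, or a phenyl carrying an amine or a carboxylic acid, would read in this assay.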